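A Nitrogen Enters the Fused Ring of Compound 1

The compounds below may be only part of what the source reports. "The series", "measured", "known", "first", "only" and "open" are said of these compounds alone.

Compound 1 `c1ccc2c(c1)CN[C@H](CN(CCCN1CCNCC1)[C@H]1CCCc3cccnc31)C2` stands highest of the three numbers in a functional assay on CCRF-CEM cells for antagonist activity at C-X-C chemokine receptor type 4 (Homo sapiens), read by calcium flux, with stated times of 25 min and 90 s (on this read-out lower numbers stand for stronger inhibition and higher numbers for weaker inhibition), where compound 1 gives 1150 nM. Compound 3 `CN1CCN(CCCN(C[C@H]2Cc3ccccc3CN2C)[C@H]2CCCc3cccnc32)CC1` gives 536 nM in this assay, and compound 2 `c1ccc2c(c1)CN[C@@H](CN(CC[C@@H]1CCCNC1)[C@H]1CCCc3cccnc31)C2` gives 161 nM, each a lower number than compound 1 by more than the scatter. Compound 4 `c1cnc2c(c1)CN[C@H](CN(CCCN1CCNCC1)[C@H]1CCCc3cccnc31)C2` differs from compound 1 by a group of 10 heavy atoms (8 carbon, 2 nitrogen; one six-membered non-aromatic ring with 1 hetero atom, one six-membered aromatic ring with 1 hetero atom) in place of a group of 10 heavy atoms (9 carbon, 1 nitrogen; one six-membered non-aromatic ring with 1 hetero atom, one six-membered aromatic ring of carbon only), on a saturated chain carbon bound to an amine nitrogen. For the measured compounds named here, no measured pair shows this kind of change, so its effect in this assay is unknown; a step of modest size in either direction, or none beyond the scatter, is expected. Compound 4 is therefore estimated at 950 nM, with a range from 300 nM to 3000 nM. The estimate corresponds to an expected step of a 1.2-fold lower number from compound 1 to compound 4 (0.08 log units; within the scatter) that remains within the scatter.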

Compound 4, half-maximal inhibitory concentration: 2640 nM
Compound 4: middle estimate off by 2.8-fold (0.44 log units), on the low side; measured number inside the range.
By their numbers in this assay, from the lowest: compound 2; then compound 3; then compound 1; then compound 4.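

In this assay, putting a nitrogen into the aromatic ring of the 1,2,3,4-tetrahydroisoquinolin-3-yl group brings a 2.3-fold higher number from compound 1 to compound 4 (0.36 log units; beyond the scatter), so inhibition weakens. This is the first single-place comparison among these compounds, and it shows that this group does not tolerate every change to its aromatic ring without a shift in the number. Nothing available explains the shift. Open, going by these compounds, is whether a fluorine or a methoxy group on the carbon-only aromatic ring would move the number in the same direction, or the opposite one.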